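A few compounds are considered here, and "the series" means these few. Any claim that something is new, unique, unknown or untested is made for them only; others in the source may bear on it.

Within the data shown here, in an ADME assay on Vero cells (Chlorocebus sabaeus) for cytotoxicity, with a stated time of 72 h (a lower number here means that less compound is tolerated, a higher number that more compound is tolerated), compound 1 (`CN1CCN(c2ccc(C(=O)C3CC3c3ccc(Cl)cc3)cc2)CC1`) gives 82.1 ug/mL, while compound 2 (`CN(C)CCCNc1ccc(C(=O)C2CC2c2ccc(Cl)cc2)cc1`) gives 15.8 ug/mL, the lower of the two numbers measured so far. Compound 3 (`O=C(c1ccc(N2CCCCC2)cc1)C1CC1c1ccc(Cl)cc1`) has not yet been measured. It keeps the shared core and differs from compound 2 in one group: piperidin-1-yl in place of (3-(dimethylamino)propyl)amino on an aromatic carbon. In words, piperidin-1-yl takes the place of (3-(dimethylamino)propyl)amino on an aromatic carbon. Among the measured compounds shown here, only one measured step bears on this change: a 5.2-fold lower number from compound 1 to compound 2 (0.72 log units; beyond the scatter), where the same chain replaced 4-methylpiperazin-1-yl. The entering group in compound 3 is also a ring, though not the same one, so a move back towards a higher number is expected, of similar or somewhat smaller size. A single step is thin evidence, so the range is wide. The expected step is a 3.2-fold higher number from compound 2 to compound 3 (0.50 log units; beyond the scatter). For compound 3 the estimated value is 50 ug/mL, with an expected range from 20 ug/mL to 120 ug/mL.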

Compound 3, half-maximal cytotoxic concentration: 284 ug/mL
Beside the measured number, compound 3's estimate is 5.7-fold (0.75 log units) below it; measured number outside the range, above it.
By their numbers in this assay, from the lowest: compound 2; then compound 1; then compound 3.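

In this assay, piperidin-1-yl in place of the chain at this aromatic carbon gives an 18-fold higher number from compound 2 to compound 3 (1.25 log units; beyond the scatter) and so goes much further than a simple return to the level of the earlier ring compound. The two rings also differ from each other, since piperidin-1-yl in place of 4-methylpiperazin-1-yl gives a 3.5-fold higher number from compound 1 to compound 3 (0.54 log units; beyond the scatter) and puts compound 3 highest of the three, so the number depends on which ring sits here and not only on there being a ring. Nothing available explains these differences.

Among these compounds, with only three compounds on one core, the trend rests on a single open chain and two rings. A morpholin-4-yl ring, a pyrrolidin-1-yl ring or a simple butylamino chain could each fall anywhere relative to these three.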